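Chloro on the Benzoyl Ring of a Tetrahydroquinoline Amide

The source may hold more compounds than are shown below. What is called first, only, known or untested is meant among the compounds shown, and "the series" means these compounds.

Measured compounds:
Compound 1 `O=C(Nc1ccccc1O)C1CCc2ccccc2N1C(=O)c1ccccc1Cl` gives 46900 nM in a functional assay on NCI-H23 cells (Homo sapiens) for cytotoxicity, read by sulforhodamine B assay, with a stated time of 72 h; on this read-out higher numbers stand for weaker inhibition of growth and lower numbers for stronger inhibition of growth.
Compound 2 `O=C(Nc1ccccc1O)C1CCc2ccccc2N1C(=O)c1ccccc1` gives 3490 nM in this assay.
Compound 3 `O=C(Nc1cc(C(F)(F)F)cc(C(F)(F)F)c1)C1CCc2ccccc2N1C(=O)c1ccccc1` gives 2130 nM in this assay.

Compound 4 `O=C(Nc1cc(C(F)(F)F)cc(C(F)(F)F)c1)C1CCc2ccccc2N1C(=O)c1cccc(Cl)c1` has not been measured. It differs from compound 3 by chloro in place of hydrogen on an aromatic carbon. The same kind of change has been measured once, from compound 2 to compound 1, as chloro in place of hydrogen on an aromatic carbon, and there it gave a 13-fold higher number from compound 2 to compound 1 (1.13 log units; beyond the scatter). The two places are not identical: in compound 1 the chloro sits ortho to a large group, in compound 4 meta to a large group, so this is the same kind of change, not the same. The difference between the cores of compound 2 and compound 3 is not broken down here; their values lie within the scatter of each other. Weaker inhibition of growth for compound 4 is expected, with the expected step being a 2.1-fold higher number from compound 3 to compound 4 (0.32 log units; beyond the scatter), smaller than the earlier step, and wide uncertainty. In this assay compound 4 is estimated at 4500 nM, within 1500 nM to 15000 nM.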

Compound 4, concentration for 50% growth inhibition: 420 nM
Beside the measured number, compound 4's estimate is 11-fold (1.03 log units) above it, and the stated range ends above it.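

In this assay, putting chloro in place of hydrogen on the benzoyl ring gave a 5.1-fold lower number from compound 3 to compound 4 (0.71 log units; beyond the scatter), so the change did not carry its direction over from the earlier pair: the same change on two cores in this assay, a 13-fold higher number (1.13 log units; beyond the scatter) from compound 2 to compound 1 and a 5.1-fold lower number (0.71 log units; beyond the scatter) from compound 3 to compound 4, 68-fold (1.83 log units) apart, beyond the scatter of two such steps

On this evidence, the direction of a chloro step cannot be taken from one core to another in this series. The two pairs differ both in the core and in where the chloro sits, and the compounds shown do not separate these two differences.

From the compounds shown here alone, it remains open what the 3-chlorophenyl group would give on the core of compound 2, and what the chloro placement of compound 1 would give on the core of compound 3. Going by these compounds, whether a fluoro, methyl or methoxy group at that place would follow chloro is also open.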